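The source may hold more compounds than are shown below. What is called first, only, known or untested is meant among the compounds shown, and "the series" means these compounds.

Measured compounds:
- Compound 1 `CC(C)n1c(/C=C2\SC(=O)N(CC(=O)N3CCOCC3)C2=O)nc2ccccc21`: in a functional assay on DU-145 cells (Homo sapiens) for inhibition, read by MTT assay, with a stated time of 48 h (on this read-out lower numbers stand for stronger inhibition and higher numbers for weaker inhibition), compound 1 gives > 50000 nM, a limit of the assay and not a number.
- Compound 2 `CCn1c(/C=C2\SC(=O)N(CC(=O)N3CCOCC3)C2=O)nc2ccccc21`: in this assay compound 2 gives > 50000 nM, likewise a limit of the assay.

Compound 1 therefore stands at the limit itself, with no measured number to anchor it. For the measured compounds named here, the one measured step, a step that the two limits leave unreadable from compound 1 to compound 2, runs between two limits, so its size cannot be read; the limit of > 50000 nM in this assay, at which 2 of the 2 values shown sit, shows both values sitting at that same limit.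

Compound 3 `CC1CN(C(=O)CN2C(=O)S/C(=C\c3nc4ccccc4n3C(C)C)C2=O)CC(C)O1` differs from compound 1 by 2,6-dimethylmorpholin-4-yl in place of morpholin-4-yl on a carbonyl carbon. Going by the values given here, no measured step touches the group on the carbonyl carbon, and the only comparison available is unreadable, so no step in this assay beyond the scatter can be expected in either direction; a further limit is the most likely outcome. Compound 3 is estimated near 70000 nM, with a range from 20000 nM to 250000 nM. The expected step is a step that the limit leaves unreadable from compound 1 to compound 3.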

Compound 3, half-maximal inhibitory concentration: > 50000 nM
Compound 3 was reported as a limit; the forecaster's own chance of this, stated with the estimate: 80%; the middle value lies beyond the limit too.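

In this assay compound 3 gives > 50000 nM as a limit of the assay and not a number. No step from compound 1 to compound 3 can be read, with both compounds at the same limit: the limit of > 50000 nM in this assay, at which 3 of the 3 values shown sit.

Going by these compounds, whether compound 1, compound 2 and compound 3 differ at all in inhibition stays open, as does which change on the shared core would give a measurable value.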